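Phenyl for Methyl on the Chain of Compound 1

The compounds below may be only part of what the source reports. "The series", "measured", "known", "first", "only" and "open" are said of these compounds alone.

Measured compounds:
- compound 1, `CCn1c(=O)n(C2OC(CO)[C@@H](O)[C@H]2O)c2nc(N)nc(O)c21`: 15 uM
- compound 2, `C=CCn1c(=S)n([C@@H]2O[C@H](CO)[C@H]3OC(C)(C)O[C@H]32)c2nc(N)nc(O)c21`: 55 uM

Both compounds were tested in a functional assay (B cells) with Mus musculus as the target; on this read-out higher numbers stand for an effect only at larger amounts of compound and lower numbers for an effect already at smaller amounts. Compound 1 gives 15 uM and compound 2 gives 55 uM, so compound 1 stands at the lower of the two numbers, with compound 2 beyond the scatter above it. Compound 2 differs from compound 1 in several places at once, so no single step can be read from that pair.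

Compound 3, `Nc1nc(O)c2c(n1)n(C1OC(CO)[C@@H](O)[C@H]1O)c(=O)n2Cc1ccccc1`, has not yet been measured in this assay. It differs from compound 1 in one place: phenyl in place of methyl on a saturated chain carbon bound to an aromatic nitrogen. Among the compounds with values here, no comparable single step is known among the measured compounds, so the direction of the change is uncertain. A modest step in this assay is expected, somewhat toward a higher number, which for compound 3 means an estimated 20 uM with a range from 5 uM to 80 uM. The step expected from compound 1 is a 1.3-fold higher number from compound 1 to compound 3 (0.12 log units; within the scatter).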

Compound 3, concentration for half-maximal effect: 6 uM
Beside the measured number, compound 3's estimate is 3.3-fold (0.52 log units) above it; the range from low to high includes it.
By their numbers in this assay, from the lowest: compound 3; then compound 1; then compound 2.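

In this assay, within the data shown here, phenyl in place of methyl on a saturated chain carbon bound to an aromatic nitrogen gives a 2.5-fold lower number from compound 1 to compound 3 (0.40 log units; beyond the scatter), the first single change that can be read at this position. Ethyl can therefore give way to benzyl, with its six-membered aromatic ring, and the effect still appears at smaller amounts of compound. This shows that the position accepts a much larger group without a move toward a higher number, although no available measurement gives a reason for the step.

On these data alone, it remains open whether a longer chain ending in phenyl, such as phenylethyl, would shift the number further. It is also unknown how an amine or a carboxylic acid on the phenyl ring would change the result.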